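The source may hold more compounds than are shown below. What is called first, only, known or untested is meant among the compounds shown, and "the series" means these compounds.

Compound 3 `COc1cc(-c2nn(-c3cccc(NC(=O)c4ccc(Cl)c(C(F)(F)F)c4)c3)cc2-c2ccncc2)ccc1Cl` carries an aryl amide on the shared core, and in a functional assay on OVCAR-5 cells (Homo sapiens) for inhibition, read by sulforhodamine B assay, with a stated time of 48 h (a lower number here means a stronger inhibitor of growth, a higher number a weaker inhibitor of growth), compound 3 gives > 32500 nM, a limit of the assay rather than a number. Its two urea companions are compound 1 `COc1cc(-c2nn(-c3cccc(NC(=O)Nc4ccc(Cl)c(Cl)c4)c3)cc2-c2ccncc2)ccc1Cl` and compound 2 `COc1cc(-c2nn(-c3cccc(NC(=O)Nc4cccc(C(F)(F)F)c4)c3)cc2-c2ccncc2)ccc1Cl`. In this assay compound 1 gives > 50000 nM, again a limit. In this assay compound 2 gives 6450 nM. The step of an at least 5.0-fold higher number from compound 2 to compound 3 (0.70 log units; beyond the scatter) therefore runs from a urea to an amide, while the step that the two limits leave unreadable from compound 1 to compound 3 cannot be read because both of its ends sit at limits the limit of > 32500 nM in this assay, at which 1 of the 3 values shown sits (the limit of > 50000 nM in this assay, at which 1 of the 3 values shown sits).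

Compound 4 `COc1cc(-c2nn(-c3cccc(NC(=O)Nc4ccc(Cl)c(C(F)(F)F)c4)c3)cc2-c2ccncc2)ccc1Cl` is the urea that matches the amide of compound 3: (4-chloro-3-(trifluoromethyl)phenyl)amino in place of 4-chloro-3-(trifluoromethyl)phenyl on a carbonyl carbon. Among the compounds with values here, the only readable comparison of this kind, an at least 5.0-fold higher number from compound 2 to compound 3 (0.70 log units; beyond the scatter), went toward weaker growth inhibition when the urea became an amide, so reversing it is expected to bring a lower number in this assay, with the uncertainty that compound 1, a urea, also stays at a limit. Compound 4 is expected to give about 12000 nM in this assay, within 3000 nM to 50000 nM, which would mean the step of an at least 2.7-fold lower number from compound 3 to compound 4 (0.43 log units; beyond the scatter).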

Compound 4, concentration for total growth inhibition: 11000 nM
The estimate for compound 4 lay 1.1-fold (0.04 log units) above the measured number, within the range that was stated.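

In this assay, going by these compounds, holding 4-chloro-3-(trifluoromethyl)phenyl fixed gives a direct amide-to-urea comparison, an at least 2.9-fold lower number from compound 3 to compound 4 (0.47 log units; beyond the scatter), and its exact size stays open because compound 3 stands at a limit: the limit of > 32500 nM in this assay, at which 1 of the 4 values shown sits. Among the ureas, chloro in place of hydrogen on an aromatic carbon stays within the scatter, a 1.7-fold higher number from compound 2 to compound 4 (0.23 log units; within the scatter), so this added chloro shows no readable effect on the number. Trifluoromethyl in place of chloro on an aromatic carbon does register, an at least 4.5-fold lower number from compound 1 to compound 4 (0.65 log units; beyond the scatter), and this step too has no exact size because compound 1 stands at a limit: the limit of > 50000 nM in this assay, at which 1 of the 4 values shown sits.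

The compounds shown leave open whether the urea gain holds for aryl groups other than this one. They also leave open how a carboxylic acid or a morpholine in place of the trifluoromethyl would read in this assay.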